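Adding a Propyl Group to the Ring of Compound 1

This account rests on a few compounds, and the source may have more. Where it says the series, first, only, none or still open, it means among the compounds named here.

Compound 1 `CCCc1cc(C(C)=O)c(O)cc1OCCCCC#N` stands highest of the three measured compounds in an assay on isolated protein for inhibition of leukotriene B4 receptor 1 (Homo sapiens), tested at 10 uM (a lower number here means less inhibition, a higher number more inhibition at the concentration tested (going by the name of the read-out)), where compound 1 gives 84%. Compound 2 `CCCCCc1cc(C(C)=O)c(O)cc1OCCCCC#N` gives 31% in this assay, and compound 3 `CC(=O)c1cc(CC(C)O)c(OCCCCC#N)cc1O` gives 10%. The step of a number 53 percentage points lower from compound 1 to compound 2 (beyond the scatter) and the step of a number 74 percentage points lower from compound 1 to compound 3 (beyond the scatter) both show that enlarging or decorating the saturated chain on the core of compound 1 lowers the number sharply, while the step of a number 21 percentage points lower from compound 2 to compound 3 (beyond the scatter) is smaller. Compound 4 `CCCc1cc(C(C)=O)c(O)c(CCC)c1OCCCCC#N` differs from compound 1 by propyl in place of hydrogen on an aromatic carbon. Going by the values given here, no measured step places a new group on an aromatic carbon, so the two large steps away from compound 1 are only indirect guides; still, every addition to compound 1 measured here has reduced inhibition, and a decrease beyond the scatter is expected, though of less certain size than those chain changes. Compound 4 is expected to give about 55%, within 25% to 85%. This corresponds to an expected step of a number 29 percentage points lower from compound 1 to compound 4 (beyond the scatter).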

Compound 4, a percentage reported as inhibition, at one concentration (the size of the read-out at that concentration, not a potency): 0%
The estimate for compound 4 lay 55 percentage points above the measured number, and the stated range ends above it.
By their numbers in this assay, from the lowest: compounds 4 and 3 (each within the scatter of the next); then compound 2; then compound 1.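

The earlier steps shown here on saturated chains could not reveal what a substituent on this aromatic carbon, ortho to a 4-cyanobutoxy group and ortho to a hydroxy group, does to the number: propyl in place of hydrogen gives a number 84 percentage points lower from compound 1 to compound 4 (beyond the scatter). In this assay compound 4 gives 0%, so this single addition to the core of compound 1 removes all the inhibition read at the concentration tested, and a change on the ring alone is enough to do so.

Going by these compounds, whether methyl or a fluorine atom on this same aromatic carbon would keep any of the inhibition seen with compound 1 remains open. No measurement on hand explains why propyl here has this outcome, so the reason for the loss stays unknown.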